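A few compounds are considered here, and "the series" means these few. Any claim that something is new, unique, unknown or untested is made for them only; others in the source may bear on it.

Working notes on the series, read in a physicochemical assay for lipophilicity, using the shake flask method, in phosphate buffer, measured as octanol-water partition, with a stated time of 30 min, at pH 7.4; a lower number here means a more polar compound, a higher number a more lipophilic compound. Compound 1 (`Fc1ccc2c(c1CNc1ncc(Oc3ccccc3)c3nncn13)CCO2`) gives 3.5, the highest of the three numbers available. Compound 2 (`Cc1ncccc1-c1cnc(NCc2c(F)ccc3c2CCO3)c2n[nH]c(=O)n12`) gives 2.5. Compound 3 (`CN(C)C(=O)c1cc(-c2cnc(NCc3c(F)ccc4c3CCO4)c3cn[nH]c(=O)c23)n(C)n1`) gives 2.1. Both lie lower than compound 1 by more than the usual scatter, but no two of these three compounds differ in one place only, so no single change has a measured step behind it.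

Compound 4 (`CN(c1ccccc1)c1cnc(NCc2c(F)ccc3c2CCO3)n2cnnc12`) has no number yet and departs from compound 1 in one place: methyl(phenyl)amino in place of phenoxy on an aromatic carbon. In words, methyl(phenyl)amino stands in place of phenoxy on an aromatic carbon, and each group carries one six-membered aromatic ring of carbon only. Going by the values given here, with no measured step to draw on, the expectation starts from compound 1 at 3.5, and no step beyond the scatter is expected in this assay, in either direction. The expected change is a number 0.10 log units higher from compound 1 to compound 4 (within the scatter). For compound 4 the estimate is 3.6, with an expected range of 3.1 to 4.1.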

Compound 4, distribution coefficient: 3.6
The estimate for compound 4 equals the measured number at the digits printed; measured number inside the range.
By their numbers in this assay, from the lowest: compound 3; then compound 2; then compounds 1 and 4 (each within the scatter of the next).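

Going by these compounds alone, this is the first step measured in one place: in this assay, methyl(phenyl)amino in place of phenoxy on an aromatic carbon gives a number 0.10 log units higher from compound 1 to compound 4 (within the scatter). At this position, ortho to a fused ring and para to a large group, one group bearing a six-membered aromatic ring of carbon only can thus stand in for another, the linking oxygen giving way to a methyl-bearing nitrogen, without a step beyond the scatter. No measurement on hand offers an explanation for this result.

Open, going by these compounds, is whether a group without that aromatic ring at this position, such as morpholine or a carboxylic acid, would give a step beyond the scatter. This single step also cannot show whether the same exchange would behave alike on a different core.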